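The source may hold more compounds than are shown below. What is called first, only, known or untested is meant among the compounds shown, and "the series" means these compounds.

The compounds share one core, carrying a bromine, an amide and an amino side chain. Compound 1 `C[C@@H](Nc1c(C(=O)NCc2ccc(F)cc2)nc(Br)c2cccnc12)c1ccccc1` bears a 1-phenylethyl group on that nitrogen. In a functional assay on MDA-MB-435 cells (Homo sapiens) for cytotoxicity, read by MTT assay, with a stated time of 72 h (a lower number here means a stronger inhibitor, a higher number a weaker inhibitor), compound 1 gives only a limit, > 20000 nM. Compound 2 `COC(=O)CNc1c(C(=O)NCc2ccc(F)cc2)nc(Br)c2cccnc12` carries (methoxycarbonyl)methyl instead, and in this assay compound 2 gives 10000 nM; that change is an at least 2.0-fold lower number from compound 1 to compound 2 (0.30 log units; that floor lies within the scatter). Compound 3 `N[C@H]1CC[C@H](Nc2c(C(=O)Nc3ccccc3)nc(Br)c3cccnc23)CC1` differs from compound 2 in two places, at the amide and at the amine, and in this assay compound 3 gives 1000 nM. Among the measured compounds shown here, of the two numbers known, compound 2 has the highest, and compound 3 sits beyond the scatter below it.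

Compound 4 `NCCCNc1c(C(=O)NCc2ccc(F)cc2)nc(Br)c2cccnc12` is the next compound; it differs from compound 2 by 2-aminoethyl in place of methoxycarbonyl on a saturated chain carbon bound to a nitrogen on an aromatic ring. For the measured compounds named here, the only measured step on this side chain is an at least 2.0-fold lower number from compound 1 to compound 2 (0.30 log units; that floor lies within the scatter), whose floor lies within the scatter, so it gives little guidance. Compound 3 also carries a primary amine on its side chain and gives the lower number, but it differs at the amide too, so its value alone cannot be read as the effect of the amine. A modest step down is therefore expected, a 3.3-fold lower number from compound 2 to compound 4 (0.52 log units; beyond the scatter). Compound 4 is estimated at 3000 nM, within 800 nM to 12000 nM.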

Compound 4, half-maximal inhibitory concentration: 5000 nM
Compound 4: middle estimate off by 1.7-fold (0.22 log units), on the low side, and the stated range covers the measured number.
By their numbers in this assay, from the lowest: compound 3; then compounds 4 and 2 (each within the scatter of the next). At a limit, above all of these: compound 1.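

In this assay, with the amide unchanged, replacing (methoxycarbonyl)methyl with 3-aminopropyl on the nitrogen gives a 2.0-fold lower number from compound 2 to compound 4 (0.30 log units; within the scatter). This position therefore takes a chain ending in a primary amine or one ending in methoxycarbonyl with no difference that can be told from the scatter. Measured against 1-phenylethyl, the same 3-aminopropyl chain gives an at least 4.0-fold lower number from compound 1 to compound 4 (0.60 log units; beyond the scatter), the first step on this side chain to clear the scatter, but compound 1 gives only a limit, so that step is a floor and its true size is unknown: the limit of > 20000 nM in this assay, at which 1 of the 4 values shown sits.

Still open, as far as these compounds go, is whether a shorter or longer amino chain, or a carboxylic acid at the end of the chain in place of the amine, would move the number beyond the scatter from that of compound 4. Also open, from the compounds shown here alone, is the part played by the amide, since compound 4 and compound 3 differ in two places, and the 1000 nM of compound 3 cannot be divided between its amide and its side chain.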